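Acyl change on the ring nitrogen: working notes

The source may report more compounds than this note shows. Statements on the series, on what has been measured and on what is new or still open speak of the compounds shown alone.

Measured compounds:
compound 1 `O=C(Nc1cc(C(F)(F)F)cc(C(F)(F)F)c1)C1CCc2ccccc2N1C(=O)c1ccccc1Cl`: 8040 nM
compound 2 `CC(=O)N1c2ccccc2CCC1C(=O)Nc1cc(C(F)(F)F)cc(C(F)(F)F)c1`: > 70000 nM
compound 3 `CC(=O)N1c2ccccc2CCC1C(=O)Nc1ccccc1C(F)(F)F`: > 80000 nM

All three were tested in a functional assay on PC-3 cells (Homo sapiens) for cytotoxicity, read by sulforhodamine B assay, with a stated time of 72 h; a lower number here means a stronger inhibitor of growth, a higher number a weaker inhibitor of growth. Compound 1 gives 8040 nM. For compound 2 the result is a limit of the assay, > 70000 nM. For compound 3 the result is likewise a limit of the assay, > 80000 nM.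

Among the compounds with values here, the one counted change in the set is 2-chlorophenyl in place of methyl on a carbonyl carbon; it gave an at least 8.7-fold lower number from compound 2 to compound 1 (0.93 log units; beyond the scatter). The difference between the cores of compound 2 and compound 3 is not broken down here.

Compound 4 `O=C(Nc1ccccc1C(F)(F)F)C1CCc2ccccc2N1C(=O)c1ccccc1Cl` is not yet measured. It differs from compound 3 by 2-chlorophenyl in place of methyl on a carbonyl carbon, the same change as between compound 2 and compound 1, at the same place.

The step from compound 3 to compound 4 is expected to be of roughly the size seen before, resting on an at least 8.7-fold lower number from compound 2 to compound 1 (0.93 log units; beyond the scatter); since compound 3 sits at a limit, its starting point is uncertain. The expected step is an at least 5.3-fold lower number from compound 3 to compound 4 (0.72 log units; beyond the scatter). In this assay compound 4 is estimated at 15000 nM, between 3000 nM and 80000 nM.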

Compound 4, concentration for 50% growth inhibition: 5140 nM
For compound 4 the middle estimate is 2.9-fold (0.47 log units) above the measured one; low and high end bracket the measured number.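

In this assay, 2-chlorophenyl in place of methyl on a carbonyl carbon gives an at least 15-fold lower number from compound 3 to compound 4 (1.19 log units; beyond the scatter), so the change points the same way on both cores shown, with both steps beyond the scatter: the same change on two cores in this assay, an at least 8.7-fold lower number (0.93 log units; beyond the scatter) from compound 2 to compound 1 and an at least 15-fold lower number (1.19 log units; beyond the scatter) from compound 3 to compound 4; the limit leaves it open whether they differ. For compound 3 the value > 80000 nM is a limit of the assay. For compound 2 the value > 70000 nM is likewise a limit, so both steps are lower bounds only and do not show whether the change is worth more on one core than on the other.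

Going by these compounds, only methyl and 2-chlorophenyl appear on this carbonyl carbon, so it stays open whether the lower number needs the chlorine or the aromatic ring alone, which a plain phenyl, a longer chain or a ring bearing an amine would help to separate. Also open, on these data alone, is whether the change carries over to amides that bear a methoxy group or a carboxylic acid in place of trifluoromethyl on the other aromatic ring.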